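The compounds below may be only part of what the source reports. "The series", "measured", "known", "first", "only" and "open" are said of these compounds alone.

Compound 1, `O=C1N/C(=N/c2csc(-c3ccc(Cl)cc3)c2)S/C1=C\c1ccc2ccccc2c1`, gives 3000 nM in a functional assay on HCT-116 cells (Homo sapiens) for cytotoxicity, read by MTT assay, with a stated time of 72 h; on this read-out lower numbers stand for stronger inhibition and higher numbers for weaker inhibition.
Compound 2, `O=C1N/C(=N/c2csc(-c3ccc(Cl)cc3)c2)S/C1=C\c1ccc(F)cc1`, gives 7400 nM in this assay.
Compound 3, `O=C1N/C(=N/c2nc(-c3ccc(Cl)cc3)cs2)S/C1=C\c1ccc2ccccc2c1`, gives 1200 nM in this assay.

Of the compounds shown here, three have been measured so far, and a fourth, compound 4, `O=C1N/C(=N/c2nc(-c3ccc(Cl)cc3)cs2)S/C1=C\c1ccc(F)cc1`, is still to be tested in this assay. Compound 3 stands lowest of the three, with compound 1 nearest and compound 2 furthest from it. The difference between the core of compound 3 and the core of compound 1 is not broken down here.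

The change that turns compound 3 into compound 4 is 4-fluorophenyl in place of naphthalen-2-yl on a double-bonded chain carbon bound to a double-bonded ring carbon. The same change has already been made once, from compound 1 to compound 2, where it is 4-fluorophenyl in place of naphthalen-2-yl on a double-bonded chain carbon bound to a double-bonded ring carbon. That step was a 2.5-fold higher number from compound 1 to compound 2 (0.39 log units; beyond the scatter). Since the two changes are the same change, made at the same place, it is reasonable to expect a step of about the same size from compound 3 to compound 4.

Compound 4 is therefore expected to give a step of a 2.5-fold higher number from compound 3 to compound 4 (0.40 log units; beyond the scatter) in this assay, resting on the step of a 2.5-fold higher number from compound 1 to compound 2 (0.39 log units; beyond the scatter) seen on the other core. Compound 4 is estimated at 3000 nM, with a range from 1500 nM to 6500 nM, because compound 3 gives 1200 nM and the change has so far been seen only once.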

Compound 4, half-maximal inhibitory concentration: 7500 nM
Estimate against measurement, compound 4: 2.5-fold (0.40 log units) below, and the stated range ends below it.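

In this assay, putting 4-fluorophenyl in place of naphthalen-2-yl on a double-bonded chain carbon bound to a double-bonded ring carbon gives a 6.3-fold higher number from compound 3 to compound 4 (0.80 log units; beyond the scatter), so inhibition weakens on this core as it did on the core of compound 1. The direction of the change carries over, and the two steps, though different in their printed sizes, cannot be told apart given the usual spread of such measurements: the same change on two cores in this assay, a 2.5-fold higher number (0.39 log units; beyond the scatter) from compound 1 to compound 2 and a 6.3-fold higher number (0.80 log units; beyond the scatter) from compound 3 to compound 4, 2.5-fold (0.40 log units) apart, within the scatter of two such steps. Among the compounds shown here, this shows that, for this one exchange of groups, the step seen on one core was a fair guide in direction and within scatter in size on the other, but with only two cores and a single pair of groups it does not establish a fixed step size, nor does it show that the larger step on the core of compound 3 is a real feature of that core or that the agreement would extend to further cores.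

The compounds shown leave open how other groups at this place would behave, such as a plain phenyl, a phenyl carrying an amine or a carboxylic acid, or a longer chain. They also leave open whether the step would hold if the 4-chlorophenyl group shared by all four compounds were exchanged for another group.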